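This account rests on a few compounds, and the source may have more. Where it says the series, first, only, none or still open, it means among the compounds named here.

Three nucleoside-like compounds have been tested in an ADME assay on MRC5 cells (Homo sapiens), read by MTT assay, with a stated time of 72 h (on this read-out lower numbers stand for stronger inhibition and higher numbers for weaker inhibition), so far. Compound 1 `CNc1ncnc2c1c(-c1ccsc1)cn2[C@@H]1O[C@H](CO)[C@@H](O)[C@H]1O` carries a thiophen-3-yl group on the shared core and a methylamino group; in this assay compound 1 reaches only the limit of > 100000 nM, which is not a number. Compound 2 `O=c1[nH]cnc2c1c(-c1ccsc1)cn2[C@@H]1O[C@H](CO)[C@@H](O)[C@H]1O` keeps the thiophen-3-yl group and bears a ring carbonyl with an amide hydrogen instead; in this assay compound 2 likewise gives only the limit of > 100000 nM. Compound 3 `Cc1ncnc2c1c(-c1ccoc1)cn2[C@@H]1O[C@H](CO)[C@@H](O)[C@H]1O` carries a furan-3-yl group and a methyl group, and in this assay compound 3 gives 98300 nM, a measured number. Compound 2 therefore stands at the limit of > 100000 nM in this assay, at which 2 of the 3 values shown sit, with nothing in the set clearly stronger.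

Compound 4 `O=c1[nH]cnc2c1c(-c1ccoc1)cn2[C@@H]1O[C@H](CO)[C@@H](O)[C@H]1O` is the partner of compound 2 in which (furan-3-yl in place of thiophen-3-yl on an aromatic carbon). For the measured compounds named here, no measured pair shows what this exchange does. Given that compound 3 with a furan-3-yl group gives 98300 nM, no step beyond the usual scatter is expected, and a number no higher from compound 2 to compound 4 (the limit leaves the size open) is the estimated change. Compound 4 is expected to give about 100000 nM, within 40000 nM to 300000 nM, most likely again reported only as a limit.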

Compound 4, half-maximal inhibitory concentration: > 100000 nM
Compound 4: no number, only a limit (the forecaster's own chance of this, stated with the estimate: 70%); the middle value lies on the limit itself.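

Compound 2 and compound 4 both give only a limit in this assay, not a number, so no step can be read between them: the limit of > 100000 nM in this assay, at which 3 of the 4 values shown sit.

The compounds shown leave open what furan-3-yl in place of thiophen-3-yl does in this assay: no pair differing in that one place offers two numbers to compare.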